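This account rests on a few compounds, and the source may have more. Where it says the series, first, only, none or still open, it means among the compounds named here.

Measured compounds:
Compound 1, `O=C(CSc1c[nH]c2ccc(Cl)cc12)Nc1ccc(Cl)c(Cl)c1` — in an ADME assay on HEK-293T cells (Homo sapiens) for cytotoxicity, read by CCK-8 assay, with a stated time of 48 h (a lower number here means that less compound is tolerated, a higher number that more compound is tolerated), compound 1 gives 42700 nM.
Compound 2, `COc1ccc2[nH]cc(SCC(=O)Nc3ccc(Cl)c(Cl)c3)c2c1` — in this assay compound 2 gives 61800 nM.
Compound 3, `CCOc1ccccc1NC(=O)CSc1c[nH]c2cccc(Cl)c12` — in this assay compound 3 gives 25200 nM.

Compound 1 and compound 2 differ in one place, (methoxy in place of chloro on an aromatic carbon), and in this assay this gave a 1.4-fold higher number from compound 1 to compound 2 (0.16 log units; within the scatter). Compound 3 shares the same amide-linked arrangement but its core differs from that of compound 1 in more than one place; the difference between the two cores is not broken down here. Compound 4, `CCOc1ccccc1NC(=O)CSc1c[nH]c2cccc(OC)c12`, has not been measured. It is made from compound 3 by the same kind of change, (methoxy in place of chloro on an aromatic carbon); here the place is ortho to a fused ring and meta to a fused ring, whereas in compound 2 it is meta to a fused ring and para to a fused ring, so the two changes are of the same kind rather than the same. The step from compound 3 to compound 4 in this assay is expected to be a 1.3-fold higher number from compound 3 to compound 4 (0.10 log units; within the scatter), resting on the single earlier case, a 1.4-fold higher number from compound 1 to compound 2 (0.16 log units; within the scatter). On that basis compound 4 is estimated at 32000 nM, with a likely range from 15000 nM to 70000 nM.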

Compound 4, half-maximal cytotoxic concentration: > 100000 nM
Compound 4 ended at the assay's limit; the forecaster's own chance of this, stated with the estimate: 10%; middle value at least 3.1-fold (0.49 log units) from the limit.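

In this assay, methoxy in place of chloro on an aromatic carbon gave an at least 3.9-fold higher number from compound 3 to compound 4 (0.59 log units; beyond the scatter). This shows that the size of the step did not carry over unchanged from one core to the other in these two cases: the same change on two cores in this assay, a 1.4-fold higher number (0.16 log units; within the scatter) from compound 1 to compound 2 and an at least 3.9-fold higher number (0.59 log units; beyond the scatter) from compound 3 to compound 4, at least 2.7-fold (0.43 log units) apart, beyond the scatter of two such steps. It does not show how large the step truly is or what sets the two steps apart, and the value of compound 4 is a limit of the assay and not a number: the limit of > 100000 nM in this assay, at which 1 of the 4 values shown sits.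

The compounds shown leave open whether the gap between the steps goes with the place of the methoxy on the ring or with the rest of the molecule, as the two pairs differ in both and no pair shown holds one fixed while the other changes. They also leave open how an amine or a carboxylic acid in place of the chloro at that same place would fare in this assay.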